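From methoxy to isopropyl: little change expected

The compounds below may be only part of what the source reports. "The series", "measured", "known", "first", "only" and "open" are said of these compounds alone.

In an ADME assay on HEp-2 cells (Homo sapiens) for cytotoxicity (on this read-out lower numbers stand for higher toxicity in this test and higher numbers for lower toxicity in this test), compound 1 (`CC(C)c1ccccc1NC(=O)[C@@H]1CCCN1S(=O)(=O)c1cccc2cccnc12`) gives 29900 nM and compound 2 (`COc1ccc(C)c(NC(=O)[C@@H]2CCCN2S(=O)(=O)c2cccc3cccnc23)c1`) gives 44200 nM. Going by the values given here, these are the only two numbers available, and they lie within the scatter of each other, so compound 2 has no distinct standing yet. Compound 3 (`Cc1ccc(C(C)C)cc1NC(=O)[C@@H]1CCCN1S(=O)(=O)c1cccc2cccnc12`) differs from compound 2 by isopropyl in place of methoxy on an aromatic carbon, para to a methyl group. Among the compounds with values here, one measured step bears on this change, a 1.5-fold higher number from compound 1 to compound 2 (0.17 log units; within the scatter). That step also involves the methoxy and isopropyl groups, though on differently substituted rings, and it stays within the scatter. A step beyond the scatter in this assay is therefore not expected, and no direction can be firmly assigned. The expected change is a 1.3-fold lower number from compound 2 to compound 3 (0.10 log units; within the scatter). Compound 3 is estimated at 35000 nM, with an expected range of 16000 nM to 75000 nM.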

Compound 3, half-maximal cytotoxic concentration: 9700 nM
Estimate against measurement, compound 3: 3.6-fold (0.56 log units) above; measured number below the stated range.
By their numbers in this assay, from the lowest: compound 3; then compounds 1 and 2 (each within the scatter of the next).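

In this assay, going by these compounds alone, the place para to a methyl group turns out to matter: isopropyl in place of methoxy there brings a 4.6-fold lower number from compound 2 to compound 3 (0.66 log units; beyond the scatter) even though the only earlier step stayed within the scatter. The change from 2-isopropylphenyl to 5-isopropyl-2-methylphenyl on the amide-type nitrogen also brings a 3.1-fold lower number from compound 1 to compound 3 (0.49 log units; beyond the scatter) and so sets compound 3 apart from both other compounds, with the highest toxicity in this test of the three. No measurement at hand gives a reason for these steps.

The three compounds leave open whether an amine or a carboxylic acid at this place would move the number in the same direction as isopropyl. They also leave open whether a longer chain there would go further than isopropyl does.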